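Moving a Methyl Around the Aniline Ring

This account rests on a few compounds, and the source may have more. Where it says the series, first, only, none or still open, it means among the compounds named here.

Going by the values given here, compound 1, `COc1cc(/C=C/C(=O)c2sc(Nc3ccccc3C)nc2C)cc(OC)c1OC`, is the one compound here with a full number in a functional assay on BGC-823 cells (Homo sapiens) for cytotoxicity, read by MTT assay; a higher number here means a weaker inhibitor, a lower number a stronger inhibitor: in that assay compound 1 gives 5400 nM. Compound 2, `Cc1nc(Nc2cccc(Cl)c2)sc1C(=O)/C=C/c1ccc(Cl)cc1`, reaches only a limit of the assay, > 25000 nM, which is the limit of > 25000 nM in this assay, at which 1 of the 2 values shown sits. Among the compounds with values here, no step between two measured compounds is available, so the unmeasured compound can only be read against compound 1.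

Compound 3, `COc1cc(/C=C/C(=O)c2sc(Nc3ccc(C)cc3)nc2C)cc(OC)c1OC`, differs from compound 1 in a single place: 4-methylphenyl in place of 2-methylphenyl on a nitrogen on an aromatic ring. The methyl group stays on the same ring and only its position on that ring changes, while the shared core and the trimethoxyphenyl part of compound 1 are kept. Within the data shown here, nothing among the measured compounds shows how this shift behaves in this assay, so the expectation is modest: the expected step of a 1.2-fold lower number from compound 1 to compound 3 (0.08 log units; within the scatter) is small and may well fall within the usual scatter of repeated measurements. In this assay compound 3 is estimated at 4500 nM, with a likely range from 1500 nM to 15000 nM.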

Compound 3, half-maximal inhibitory concentration: > 25000 nM
Compound 3 gave a limit, no number (the forecaster's own chance of this, stated with the estimate: 10%); at least 5.5-fold (0.74 log units) between middle value and limit.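

Moving the methyl from 2-methylphenyl to 4-methylphenyl on the nitrogen, with the same atoms joined differently and the rest of the molecule kept, gives an at least 4.6-fold higher number from compound 1 to compound 3 (0.66 log units; beyond the scatter) in this assay. Going by these compounds alone, this is the first direct evidence that the methyl's position on this ring matters here, and the 2-methylphenyl form of compound 1 is the one that keeps a measurable effect on the cells. For compound 3 the reading is a limit of the assay and not a number, so the step fixes only the smallest possible size of the change, and the real gap may be larger, a caution that applies widely in so small a set: the limit of > 25000 nM in this assay, at which 2 of the 3 values shown sit.

What the compounds shown leave open is whether the effect depends on having a methyl at all, a question that a plain phenyl, a 2-ethylphenyl or a 2-methoxyphenyl on the same nitrogen would help to answer. On these data alone, it also remains open whether the same shift of the methyl would cost as much with another group in place of the trimethoxyphenyl part.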